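This account rests on a few compounds, and the source may have more. Where it says the series, first, only, none or still open, it means among the compounds named here.

Working notes on the series. In a functional assay on SF-268 cells (Homo sapiens) for inhibition, read by sulforhodamine B assay, with a stated time of 48 h (on this read-out higher numbers stand for weaker inhibition of growth and lower numbers for stronger inhibition of growth), compound 2 `Nc1cc(N)c2nc(-c3ccccc3)c(NCc3ccc(F)cc3)nc2c1` gives 2820 nM, the lowest of the three numbers in hand. Compound 1 `Nc1cc(N)c2nc(-c3ccccc3)c(NCc3ccc(Cl)c(Cl)c3)nc2c1` gives 20000 nM and compound 3 `COc1ccc(CNc2nc3cc(N)cc(N)c3nc2-c2ccccc2)cc1` gives 9770 nM; the steps of a 7.1-fold lower number from compound 1 to compound 2 (0.85 log units; beyond the scatter) and a 3.5-fold higher number from compound 2 to compound 3 (0.54 log units; beyond the scatter) both lie beyond the scatter, as does a 2.0-fold lower number from compound 1 to compound 3 (0.31 log units; beyond the scatter).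

Compound 4 `Nc1cc(N)c2nc(-c3ccccc3)c(Oc3ccc(F)cc3)nc2c1` is not yet measured. The change from compound 2 is 4-fluorophenoxy in place of (4-fluorobenzyl)amino on an aromatic carbon. Going by the values given here, all three measured steps alter only the aromatic substituent of the benzyl group; none of them replaces the (4-fluorobenzyl)amino group itself, so the step to compound 4 has no direct precedent here. With one hydrogen-bond donor and one saturated chain carbon removed, the direction of the step cannot be read from the measured compounds, and a wide range is needed. The working expectation is a modest rise in the number, a 2.1-fold higher number from compound 2 to compound 4 (0.33 log units; beyond the scatter), giving for compound 4 an estimated 6000 nM with a range from 1500 nM to 25000 nM.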

Compound 4, concentration for 50% growth inhibition: 13800 nM
Compound 4: the middle estimate sits 2.3-fold (0.36 log units) below what was measured; low and high end bracket the measured number.
By their numbers in this assay, from the lowest: compound 2; then compounds 3, 4 and 1 (each within the scatter of the next, the first and the last beyond it).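

The position on the aromatic carbon next to the ring nitrogen responds to a change in the link itself, not only to substituents on the outer ring: with the 4-fluorophenyl part held constant, 4-fluorophenoxy in place of (4-fluorobenzyl)amino gives a weaker result in this assay (a 4.9-fold higher number from compound 2 to compound 4 (0.69 log units; beyond the scatter)). Going by these compounds alone, compound 2 therefore remains the lowest of the four numbers, and this is the only step that alters the link. No measurement here accounts for the size or direction of this step.

The step removes the hydrogen-bond donor and the saturated chain carbon together, so their separate contributions remain unresolved. A 4-fluoroanilino group or a 4-fluorobenzyloxy group at this position would separate the two changes.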